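This account rests on a few compounds, and the source may have more. Where it says the series, first, only, none or still open, it means among the compounds named here.

Compound 1 `Cc1ccc(COc2ccc(-c3cc(CN4CCN(Cc5ccc(C(F)(F)F)cc5)CC4)no3)cc2)cc1`: 1500 nM
Compound 2 `Fc1ccc(COc2ccc(-c3cc(CN4CCN(Cc5ccc(C(F)(F)F)cc5)CC4)no3)cc2)cc1`: 2000 nM

For the measured compounds named here, in a functional assay on Huh-7 cells (Homo sapiens) for antiproliferative activity, read by sulforhodamine B assay, with a stated time of 72 h (on this read-out lower numbers stand for stronger inhibition and higher numbers for weaker inhibition), compound 2 holds the top of the two numbers, yet the only step measured, a 1.3-fold higher number from compound 1 to compound 2 (0.12 log units; within the scatter), lies within the scatter, so compound 1 and compound 2 are not separable on this read-out. Compound 3 `COc1cc(COc2ccc(-c3cc(CN4CCN(Cc5ccc(C(F)(F)F)cc5)CC4)no3)cc2)cc(OC)c1OC` differs from compound 2 by 3,4,5-trimethoxyphenyl in place of 4-fluorophenyl on a saturated chain carbon bound to an oxygen on an aromatic ring. Going by the values given here, that same benzyl ring is the one varied between compound 1 and compound 2, where the swap left the number unchanged beyond scatter; the present change is larger, and no measured step covers it. For compound 3 the expected step is no change at the digits printed from compound 2 to compound 3 (within the scatter), with the estimate in this assay at 2000 nM, ranging from 600 nM to 7000 nM.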

Compound 3, half-maximal inhibitory concentration: 500 nM
Compound 3: the middle estimate sits 4.0-fold (0.60 log units) above what was measured, outside the stated range (below it).
By their numbers in this assay, from the lowest: compound 3; then compounds 1 and 2 (each within the scatter of the next).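

In this assay, the group on a saturated chain carbon bound to an oxygen on an aromatic ring can move the number beyond the scatter: 3,4,5-trimethoxyphenyl gives a 4.0-fold lower number from compound 2 to compound 3 (0.60 log units; beyond the scatter) and a 3.0-fold lower number from compound 1 to compound 3 (0.48 log units; beyond the scatter). The earlier swap between 4-methylphenyl and 4-fluorophenyl did not show this sensitivity. Nothing available accounts for the lower number. Going by these compounds, whether a single methoxy group, as in 4-methoxyphenyl, would give a similar step remains open. So does the outcome with a phenyl ring carrying an amine or a carboxylic acid.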